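From methyl to isopropyl on the side chain

The compounds below may be only part of what the source reports. "The series", "measured", "known", "first", "only" and "open" are said of these compounds alone.

Compound 1 `CC(C)/C=C/C(=O)Nc1cccc(Oc2nc(Nc3cccc(C#N)c3)nc3c2CSCC3)c1` gives 29600 nM
Compound 2 `C=CC(=O)Nc1cccc(Oc2nc(Nc3ccc(OC)cc3)nc3c2CSCC3)c1` gives 11700 nM
Compound 3 `C/C=C/C(=O)Nc1cccc(Oc2nc(Nc3ccc(OC)cc3)nc3c2CSCC3)c1` gives 24300 nM

In a functional assay on MCF7 cells (Homo sapiens) for antiproliferative activity, read by MTT assay, with a stated time of 72 h (on this read-out higher numbers stand for weaker inhibition and lower numbers for stronger inhibition), compound 3 gives 24300 nM and so sits within the scatter of compound 1, while compound 2 lies lower, with a gap beyond the scatter. Compound 4 `COc1ccc(Nc2nc3c(c(Oc4cccc(NC(=O)/C=C/C(C)C)c4)n2)CSCC3)cc1` differs from compound 3 in one place only, and isopropyl in place of methyl on a double-bonded chain carbon bound to a double-bonded chain carbon sums up that change: isopropyl in place of methyl on a double-bonded chain carbon bound to a double-bonded chain carbon.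

Going by the values given here, the one measured step that bears on this is a 2.1-fold higher number from compound 2 to compound 3 (0.32 log units; beyond the scatter), modest in size, where prop-1-en-1-yl took the place of vinyl on a carbonyl carbon. There, a longer chain went with a higher number. Compound 1 also carries 3-methylbut-1-en-1-yl and gives 29600 nM in this assay, but no single change ties it to another measured compound, so it is only a loose guide.

A small further rise in the number is therefore expected in this assay, most likely not beyond the scatter. The estimated change is a 1.2-fold higher number from compound 3 to compound 4 (0.09 log units; within the scatter) and rests on very little evidence. Compound 4 is estimated at 30000 nM with an expected range of 15000 nM to 60000 nM on this evidence.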

Compound 4, half-maximal inhibitory concentration: > 50000 nM
Compound 4: no number, only a limit; the forecaster's own chance of this, stated with the estimate: 15%; at least 1.6-fold (0.22 log units) between middle value and limit.
By their numbers in this assay, from the lowest: compound 2; then compounds 3 and 1 (each within the scatter of the next). At a limit, above all of these: compound 4.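

In this assay compound 4 gives > 50000 nM, which is a limit of the assay and not a number. Even so, isopropyl in place of methyl on a double-bonded chain carbon bound to a double-bonded chain carbon produces an at least 2.0-fold higher number from compound 3 to compound 4 (0.31 log units; beyond the scatter), and the series with 4-methoxyphenyl held fixed now spans an at least 4.2-fold higher number from compound 2 to compound 4 (0.63 log units; beyond the scatter), so a second step beyond the scatter joins the single one seen before, running from vinyl through prop-1-en-1-yl to 3-methylbut-1-en-1-yl. With 3-methylbut-1-en-1-yl held fixed, the swap of 3-cyanophenyl for 4-methoxyphenyl gives an at least 1.6-fold higher number from compound 1 to compound 4 (0.22 log units; that floor lies within the scatter), and as that floor lies within the scatter, these two compounds cannot yet be put in order.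

Still open, going by these compounds, is whether the branching of the chain matters or simply its length, a question that a straight pent-1-en-1-yl chain at the same place would help to settle. Also open, on these data alone, are how a side chain ending in an amine such as dimethylamino would read here, and how far the true value of compound 4 lies past its limit.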